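The compounds below may be only part of what the source reports. "The series", "measured", "known", "first", "only" and "open" are said of these compounds alone.

Compound 1 `CCNC(=O)c1cc(Oc2ccc(NC(=O)c3cc4cccnc4n(-c4ccc(Br)cc4)c3=O)cc2)ccn1` gives 1160 nM in a functional assay on HT-29 cells (Homo sapiens) for antiproliferative activity, read by MTT assay, with a stated time of 72 h; a higher number here means a weaker inhibitor, a lower number a stronger inhibitor. Compound 2 `CCNC(=O)c1cc(Oc2ccc(NC(=O)c3cc4cccnc4n(-c4ccc(OC)cc4)c3=O)cc2)ccn1` differs from it by methoxy in place of bromo on an aromatic carbon, and in this assay compound 2 gives 3350 nM, a step of a 2.9-fold higher number from compound 1 to compound 2 (0.46 log units; beyond the scatter). Compound 3 `CCCNC(=O)c1cc(Oc2ccc(NC(=O)c3cc4cccnc4n(-c4ccc(Br)cc4)c3=O)cc2)ccn1` carries a different core, differing from compound 1 by methyl in place of hydrogen on a saturated chain carbon, two bonds along the chain from an amide-type nitrogen; in this assay compound 3 gives 530 nM, the step being a 2.2-fold lower number from compound 1 to compound 3 (0.34 log units; beyond the scatter). Compound 4 `CCCNC(=O)c1cc(Oc2ccc(NC(=O)c3cc4cccnc4n(-c4ccc(OC)cc4)c3=O)cc2)ccn1`, not yet measured, differs from compound 3 by methoxy in place of bromo on an aromatic carbon, the same change at the same place that separates compound 1 from compound 2. Among the measured compounds shown here, that single pair is the only guide. The step from compound 3 to compound 4 is expected to be about a 2.8-fold higher number from compound 3 to compound 4 (0.45 log units; beyond the scatter), matching the step of a 2.9-fold higher number from compound 1 to compound 2 (0.46 log units; beyond the scatter) seen on the core of compound 1. Compound 4 is accordingly estimated at 1500 nM, within a range of 700 nM to 3500 nM.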

Compound 4, half-maximal inhibitory concentration: 1560 nM
Compound 4: middle estimate off by 1.0-fold (0.02 log units), on the low side, within the range that was stated.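

In this assay, methoxy in place of bromo gives the same step on the second core, a 2.9-fold higher number from compound 3 to compound 4 (0.47 log units; beyond the scatter), as it did on the core of compound 1: the same change on two cores in this assay, a 2.9-fold higher number (0.46 log units; beyond the scatter) from compound 1 to compound 2 and a 2.9-fold higher number (0.47 log units; beyond the scatter) from compound 3 to compound 4, 1.0-fold (0.01 log units) apart, within the scatter of two such steps. Methyl in place of hydrogen on the amide chain also carries over, with a 2.1-fold lower number from compound 2 to compound 4 (0.33 log units; beyond the scatter) matching the earlier step: the same change on two cores in this assay, a 2.2-fold lower number (0.34 log units; beyond the scatter) from compound 1 to compound 3 and a 2.1-fold lower number (0.33 log units; beyond the scatter) from compound 2 to compound 4, 1.0-fold (0.01 log units) apart, within the scatter of two such steps. Across these four compounds the two changes therefore act independently of each other, but each comparison rests on just two pairs and shows nothing about cores beyond these two.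

Going by these compounds, whether the same steps would hold with chloro or a nitrile in place of bromo remains open. So does the outcome with a longer chain or a carboxylic acid on the amide.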